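The compounds below may be only part of what the source reports. "The series", "measured", "known", "first", "only" and "open" are said of these compounds alone.

In an ADME assay on CHO cells (Cricetulus griseus) for cytotoxicity, read by MTT assay (on this read-out lower numbers stand for higher toxicity in this test and higher numbers for lower toxicity in this test), compound 1 (`CN1CCN(CC2CCN(c3nccc4[nH]c(-c5ccc(F)c(F)c5)nc34)CC2)CC1`) gives 7400 nM, compound 2 (`CN1CCN(C2CCN(c3nccc4[nH]c(-c5cccc(OC(F)(F)F)c5)nc34)CC2)CC1`) gives 3000 nM and compound 3 (`NCC1CCN(c2nccc3[nH]c(-c4cccc(OC(F)(F)F)c4)nc23)CC1`) gives 2900 nM. Compound 3 thus sits level with compound 2, with compound 1 higher by a margin beyond the scatter. Compound 4 (`CN1CCN(CC2CCN(c3nccc4[nH]c(-c5cccc(OC(F)(F)F)c5)nc34)CC2)CC1`) follows from compound 3 by 4-methylpiperazin-1-yl in place of amino on a saturated chain carbon bound to a saturated ring carbon, which reads as aminomethyl to (4-methylpiperazin-1-yl)methyl. The closest measured change, a 1.0-fold lower number from compound 2 to compound 3 (0.01 log units; within the scatter), stayed within the scatter, so little movement is expected. Compound 1, which carries the same (4-methylpiperazin-1-yl)methyl group but differs elsewhere, gives 7400 nM and hints at a slight rise. The expected step is a 1.4-fold higher number from compound 3 to compound 4 (0.14 log units; within the scatter), upward but within the scatter. For compound 4 the estimated value is 4000 nM, within an expected range of 2000 nM to 8000 nM.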

Compound 4, half-maximal cytotoxic concentration: 950 nM
Beside the measured number, compound 4's estimate is 4.2-fold (0.62 log units) above it, and the stated range ends above it.
By their numbers in this assay, from the lowest: compound 4; then compounds 3 and 2 (each within the scatter of the next); then compound 1.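

Within this assay, 4-methylpiperazin-1-yl in place of amino on this saturated chain carbon gives a 3.1-fold lower number from compound 3 to compound 4 (0.48 log units; beyond the scatter) and so shows that this position is not indifferent. Moving from 4-methylpiperazin-1-yl to (4-methylpiperazin-1-yl)methyl on the saturated ring carbon gives a 3.2-fold lower number from compound 2 to compound 4 (0.50 log units; beyond the scatter), although the earlier step of a 1.0-fold lower number from compound 2 to compound 3 (0.01 log units; within the scatter) stayed within the scatter. With (4-methylpiperazin-1-yl)methyl held constant, 3-(trifluoromethoxy)phenyl in place of 3,4-difluorophenyl gives a 7.8-fold lower number from compound 1 to compound 4 (0.89 log units; beyond the scatter) and shows that the aromatic group also counts. No available evidence explains these shifts. From the compounds shown here alone, whether morpholine or dimethylamino on the same chain carbon would track 4-methylpiperazin-1-yl remains open.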